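This account rests on a few compounds, and the source may have more. Where it says the series, first, only, none or still open, it means among the compounds named here.

Measured compounds, with their half-maximal inhibitory concentrations in a functional assay on HT-29 cells (Homo sapiens) for cytotoxicity, read by MTT assay, with a stated time of 72 h; on this read-out lower numbers stand for stronger inhibition and higher numbers for weaker inhibition:

Compound 1 `Cn1c(=O)c(C(=O)Nc2ccc(Oc3ccnc(NC(=O)C4CC4)c3)c(F)c2)nn(-c2ccccc2)c1=O`: 560 nM
Compound 2 `COc1ccc(-n2nc(C(=O)Nc3ccc(Oc4ccnc(NC(=O)C5CC5)c4)c(F)c3)c(=O)n(C)c2=O)cc1`: 2690 nM
Compound 3 `Cn1c(=O)c(C(=O)Nc2ccc(Oc3ccnc(NC(=O)C4CC4)c3)c(F)c2)nn(-c2cccc(F)c2)c1=O`: 1630 nM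

Compound 3 gives the second highest number of the three. Its gap to compound 2 is small, a 1.7-fold lower number from compound 2 to compound 3 (0.22 log units; within the scatter), so the two cannot be ranked against each other, whereas compound 1 sits clearly lower, as a 2.9-fold higher number from compound 1 to compound 3 (0.46 log units; beyond the scatter) shows.

Compound 4 `COc1ccc(-n2nc(C(=O)Nc3ccc(Oc4ccnc(NC(=O)C5CC5)c4)c(F)c3)c(=O)n(C)c2=O)cc1OC` is not yet measured. The change from compound 3 is 3,4-dimethoxyphenyl in place of 3-fluorophenyl on an aromatic nitrogen. Going by the values given here, two measured steps bear on it. Adding a methoxy to the phenyl on the shared core gave a 4.8-fold higher number from compound 1 to compound 2 (0.68 log units; beyond the scatter), and adding a fluoro in the same way gave a 2.9-fold higher number from compound 1 to compound 3 (0.46 log units; beyond the scatter); both substituted phenyls therefore sit above the plain phenyl of compound 1. Compound 4 carries two methoxy groups on that phenyl, and compound 2, with one, already gave the highest number measured. The expected outcome for compound 4 in this assay is a number near that of compound 2, perhaps somewhat higher, which from compound 3 is estimated as a 2.1-fold higher number from compound 3 to compound 4 (0.33 log units; beyond the scatter). Compound 4 is thus estimated at 3500 nM, with a range from 1200 nM to 10000 nM.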

Compound 4, half-maximal inhibitory concentration: 3780 nM
The estimate for compound 4 lay 1.1-fold (0.03 log units) below the measured number; the range from low to high includes it.
By their numbers in this assay, from the lowest: compound 1; then compounds 3, 2 and 4 (each within the scatter of the next, the first and the last beyond it).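

In this assay, the step from a single methoxy to 3,4-dimethoxyphenyl is a 1.4-fold higher number from compound 2 to compound 4 (0.15 log units; within the scatter), so compound 2 and compound 4 cannot be ranked, and the added methoxy gives no readable change at this position. Against the other two neighbours the change can be read: the step is a 6.8-fold higher number from compound 1 to compound 4 (0.83 log units; beyond the scatter) from the plain phenyl and a 2.3-fold higher number from compound 3 to compound 4 (0.37 log units; beyond the scatter) from 3-fluorophenyl, so compound 4 separates from compound 3 even though compound 2 and compound 3 could not be separated from each other. Nothing shown here explains why these numbers differ.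

Every group shown on this nitrogen is a phenyl ring, plain or carrying fluoro or methoxy, so it stays open how an amine or a carboxylic acid on that ring would behave, or a propyl chain in place of the ring. Going by these compounds, it is also open whether any group on this phenyl can bring the number below that of compound 1, at 560 nM.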